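Half-life after replacing the carboxy hydroxy with piperidine

A few compounds are considered here, and "the series" means these few. Any claim that something is new, unique, unknown or untested is made for them only; others in the source may bear on it.

Values in an ADME assay (Rattus norvegicus) for pharmacokinetics (on this read-out lower numbers stand for a shorter-lived compound and higher numbers for a longer-lived compound), so far:
Compound 1 `NS(=O)(=O)c1ccccc1-c1ccc(C(=O)NCCC(=O)Nc2ccc(Br)cn2)cc1` gives 1.77 h
Compound 2 `NS(=O)(=O)c1ccccc1-c1ccc(C(=O)NC(CC(=O)Nc2ccc(Br)cn2)C(=O)O)cc1` gives 1 h

Compound 2, at 1 h, lies within the scatter of compound 1. Compound 3 `NS(=O)(=O)c1ccccc1-c1ccc(C(=O)NC(CC(=O)Nc2ccc(Br)cn2)C(=O)N2CCCCC2)cc1` differs from compound 2 by one change: piperidin-1-yl in place of hydroxy on a carbonyl carbon. In words, piperidin-1-yl stands in place of hydroxy on a carbonyl carbon, turning carboxy into (piperidin-1-yl)carbonyl.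

Within the data shown here, only one measured step bears on this. That step, a 1.8-fold lower number from compound 1 to compound 2 (0.25 log units; within the scatter), brought in the carboxy group now being altered, and it stayed inside the scatter. Among the measured compounds shown here, no measured compound carries piperidin-1-yl, so the data offer no direct guide to its effect. In this assay, no step beyond the scatter is therefore expected, though the uncertainty is wide. The estimated step is a 1.2-fold higher number from compound 2 to compound 3 (0.08 log units; within the scatter). The half-life expected for compound 3 is 1.2 h, within an estimated range of 0.5 h to 2.6 h.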

Compound 3, half-life: 1.35 h
The estimate for compound 3 lay 1.1-fold (0.05 log units) below the measured number; measured number inside the range.
By their numbers in this assay, from the lowest: compounds 2, 3 and 1 (each within the scatter of the next).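

In this assay, piperidin-1-yl in place of hydroxy on a carbonyl carbon gives a 1.4-fold higher number from compound 2 to compound 3 (0.13 log units; within the scatter), so this carbonyl carbon takes a group of six heavy atoms with a non-aromatic ring, and loses the hydroxy hydrogen-bond donor, without a step beyond the scatter. Measured against the compound with hydrogen on the saturated chain carbon, (piperidin-1-yl)carbonyl gives a 1.3-fold lower number from compound 1 to compound 3 (0.12 log units; within the scatter), so both groups now seen at this place, carboxy and (piperidin-1-yl)carbonyl, stay within the scatter of that compound. No evidence is available on what lies behind these numbers.

Going by these compounds, whether a morpholine amide, a dimethylamine amide or a methyl ester at this carbonyl carbon would also stay within the scatter remains open. So does whether any group at this place can move the half-life beyond it.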